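The compounds below may be only part of what the source reports. "The series", "measured", "known", "first", "only" and "open" are said of these compounds alone.

Of the compounds shown here, three share one core and have been tested in a functional assay on CHO cells for positive allosteric modulation of metabotropic glutamate receptor 2 (Homo sapiens), with a stated time of 30 min; a lower number here means that less compound is needed, a higher number that more compound is needed for the effect. Compound 1 `CC(C)CCn1ccc(N2CCN(c3ccccn3)CC2)c(C#N)c1=O` gives 3090 nM. Compound 2 `N#Cc1c(N2CCC(c3cccc(F)c3)CC2)ccn(CC2CC2)c1=O` gives 141 nM, and compound 3 `N#Cc1c(N2CCC(c3ccccc3Cl)CC2)ccn(CC2CC2)c1=O` gives 49 nM, the lowest of the three numbers, with compound 2 nearest to it. Within the data shown here, the only measured step between two of them is a 2.9-fold lower number from compound 2 to compound 3 (0.46 log units; beyond the scatter). Compound 4 `N#Cc1c(N2CCC(c3c(F)cccc3F)CC2)ccn(CC2CC2)c1=O` has not yet been measured; it differs from compound 3 in one place: 2,6-difluorophenyl in place of 2-chlorophenyl on a saturated ring carbon. Among the measured compounds shown here, the step from compound 2 to compound 3 is the only one that touches this position, and it was modest; no measured step swaps chlorine for fluorine there, so it bears only loosely. A small change, if any, is therefore expected, a 1.6-fold higher number from compound 3 to compound 4 (0.21 log units; within the scatter), toward slightly more compound needed. Compound 4 is expected to give 80 nM, within a range from 25 nM to 250 nM.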

Compound 4, half-maximal effective concentration: 31 nM
Compound 4: middle estimate off by 2.6-fold (0.41 log units), on the high side, within the range that was stated.
By their numbers in this assay, from the lowest: compounds 4 and 3 (each within the scatter of the next); then compound 2; then compound 1.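

Replacing the 2-chlorophenyl with 2,6-difluorophenyl gives a 1.6-fold lower number from compound 3 to compound 4 (0.20 log units; within the scatter), so the two groups cannot be told apart here. The earlier compounds had not shown that this position accepts two fluorines in place of one chlorine. Against 3-fluorophenyl, the same group gives a 4.5-fold lower number from compound 2 to compound 4 (0.66 log units; beyond the scatter), a modest step slightly larger than the one seen with 2-chlorophenyl. Still open, from the compounds shown here alone, is how a methoxy or trifluoromethyl group on this phenyl ring would compare. Nothing available explains either step.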